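The source may hold more compounds than are shown below. What is called first, only, known or untested is meant among the compounds shown, and "the series" means these compounds.

Measured so far in a functional assay on MCF7 cells (Homo sapiens) for inhibition, read by MTT assay, with a stated time of 24 h; a higher number here means a weaker inhibitor, a lower number a stronger inhibitor:
compound 1 `CCOC(=O)C1=Cc2ccccc2OC1(OCc1cn(-c2ccc(F)cc2)nn1)C(F)(F)F` gives 9100 nM.
compound 2 `CCOC(=O)C1=Cc2ccccc2OC1(OCc1cn(CC(=O)Nc2ccc(C)cc2)nn1)C(F)(F)F` gives > 150000 nM, a limit rather than a number.
compound 3 `CCOC(=O)C1=Cc2ccccc2OC1(OCc1cc(-c2ccc(Br)cc2)no1)C(F)(F)F` gives > 150000 nM, also a limit.

Compound 2 thus stands at the edge of what this assay reports: it sits at the limit of > 150000 nM in this assay, at which 2 of the 3 values shown sit. Compound 1 is the only one of the three with a number inside the range, and the step of an at least 16-fold higher number from compound 1 to compound 2 (1.21 log units; beyond the scatter) is beyond the scatter.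

The next compound, compound 4 `CCOC(=O)C1=Cc2ccccc2OC1(OCc1cn(-c2cccc(C(F)(F)F)c2)nn1)C(F)(F)F`, differs from compound 2 by 3-(trifluoromethyl)phenyl in place of ((4-methylphenyl)carbamoyl)methyl on an aromatic nitrogen. Among the compounds with values here, the one measured step that bears on this change is an at least 16-fold higher number from compound 1 to compound 2 (1.21 log units; beyond the scatter), which exchanged an aromatic group on the same aromatic nitrogen for the ((4-methylphenyl)carbamoyl)methyl group and raised the number sharply. Compound 4 runs that exchange in reverse, putting an aromatic group back on the nitrogen, though as 3-(trifluoromethyl)phenyl where compound 1 carries 4-fluorophenyl. Within the data shown here, no measured pair shows how those two aromatic groups compare, so the expectation rests on compound 1 alone.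

A large downward step in this assay is therefore expected, an at least 15-fold lower number from compound 2 to compound 4 (1.17 log units; beyond the scatter). Compound 4 is estimated at 10000 nM, with a range from 3000 nM to 40000 nM.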

Compound 4, half-maximal inhibitory concentration: > 150000 nM
Compound 4: no number, only a limit; the forecaster's own chance of this, stated with the estimate: 20%; middle value at least 15-fold (1.17 log units) from the limit.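

In this assay compound 4 gives > 150000 nM, a limit and not a number. An aromatic group on the aromatic nitrogen is therefore not enough to keep a measurable value: 3-(trifluoromethyl)phenyl in place of 4-fluorophenyl gives an at least 16-fold higher number from compound 1 to compound 4 (1.21 log units; beyond the scatter), so the identity of the aromatic group matters at this position, and the earlier contrast with ((4-methylphenyl)carbamoyl)methyl did not show this. The step from compound 2 to compound 4 cannot be read, since both ends are limits, and the series now gathers at one edge of the assay: the limit of > 150000 nM in this assay, at which 3 of the 4 values shown sit.

With compound 1 the only one giving a number, the compounds shown cannot separate the effect of swapping fluorine for trifluoromethyl from that of moving the substituent on the phenyl ring. Unsubstituted phenyl, 3-fluorophenyl or 4-(trifluoromethyl)phenyl on the same nitrogen would separate the two, while how far compound 2, compound 3 and compound 4 lie from one another stays open.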